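A few compounds are considered here, and "the series" means these few. Any claim that something is new, unique, unknown or untested is made for them only; others in the source may bear on it.

In a functional assay with Homo sapiens as the target (on this read-out higher numbers stand for weaker inhibition and lower numbers for stronger inhibition), compound 1 `CC(C)[C@H](NC(=O)COc1cccc2ccccc12)C(=O)N[C@@H](CC(=O)O)C(=O)COc1ccc(-c2ccccc2)cc1` gives 38700 nM and compound 2 `CC(C)[C@H](NC(=O)COc1cccc2ccccc12)C(=O)N[C@@H](CC(=O)O)C(=O)COc1ccccc1F` gives 15700 nM, the lower of the two numbers. Compound 3 `CC(C)[C@H](NC(=O)COc1cccc2ccccc12)C(=O)N[C@@H](CC(=O)O)C(=O)COc1cc(F)cc(F)c1` departs from compound 2 in one place: 3,5-difluorophenyl in place of 2-fluorophenyl on an oxygen on a saturated carbon, with 3,5-difluorophenyl in place of 2-fluorophenyl on an oxygen on a saturated carbon. Among the compounds with values here, only one measured step bears on this, a 2.5-fold lower number from compound 1 to compound 2 (0.39 log units; beyond the scatter), a modest change at that same place involving a much larger group. Little can be drawn from it for a swap between two fluorinated rings, so the expected change is small, estimated as a 1.1-fold lower number from compound 2 to compound 3 (0.05 log units; within the scatter). Compound 3 is expected at 14000 nM, within a range of 6000 nM to 35000 nM.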

Compound 3, half-maximal inhibitory concentration: 15900 nM
Beside the measured number, compound 3's estimate is 1.1-fold (0.06 log units) below it; the measured number falls inside the stated range.
By their numbers in this assay, from the lowest: compounds 2 and 3 (each within the scatter of the next); then compound 1.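

In this assay, 3,5-difluorophenyl in place of 2-fluorophenyl gives a 1.0-fold higher number from compound 2 to compound 3 (0.01 log units; within the scatter), so this position does not separate these two fluorinated rings. Replacing 4-phenylphenyl with 3,5-difluorophenyl gives a 2.4-fold lower number from compound 1 to compound 3 (0.39 log units; beyond the scatter), a step of the same size as a 2.5-fold lower number from compound 1 to compound 2 (0.39 log units; beyond the scatter). No measurement at hand offers a reason for either step.

This swap changes both the number and the placement of the fluorines, so their separate contributions remain unresolved. Going by these compounds, whether a plain phenyl ring, or a phenyl ring carrying an amine or a carboxylic acid, would read differently here also remains open.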